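Pyridone series: phenyl in place of thiophen-2-yl

This account rests on a few compounds, and the source may have more. Where it says the series, first, only, none or still open, it means among the compounds named here.

In a functional assay on SR cells (Homo sapiens) for inhibition, read by sulforhodamine B assay, with a stated time of 48 h (on this read-out higher numbers stand for weaker inhibition of growth and lower numbers for stronger inhibition of growth), compound 2 `Cn1cccc1-c1cc(-c2cccs2)[nH]c(=O)c1C#N` returns only a limit, > 100000 nM. Compound 3 `CC1CCCc2c1[nH]c(=O)c(C#N)c2-c1cccn1C` likewise returns a limit in this assay, > 100000 nM. Compound 1 `CC1CCCc2c1nc(N)c(C#N)c2-c1cccn1C` gives a number in this assay, 3390 nM. Compound 2 therefore stands with compound 3 at the top of the shown range, where two of the three readings sit (the limit of > 100000 nM in this assay, at which 2 of the 3 values shown sit), and only compound 1 yields a measured value. Compound 4 `Cn1cccc1-c1cc(-c2ccccc2)[nH]c(=O)c1C#N` carries the change (phenyl in place of thiophen-2-yl on an aromatic carbon), in words phenyl in place of thiophen-2-yl on an aromatic carbon. For the measured compounds named here, no measured pair isolates this change, so its size is not known from the data. Both pyridone compounds shown, compound 2 and compound 3, read as limits, while the sole numeric value belongs to compound 1 with a different core. The step expected is a number no higher from compound 2 to compound 4 (the limit leaves the size open), none beyond the scatter, with a limit again the most likely outcome. For compound 4 the expected value in this assay is 100000 nM, with a range from 30000 nM to 300000 nM.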

Compound 4, concentration for 50% growth inhibition: > 100000 nM
Compound 4: only a limit was reported (the forecaster's own chance of this, stated with the estimate: 85%); the middle value sits exactly at the limit.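

No step can be read from compound 2 to compound 4 in this assay, because each returns only a limit: the limit of > 100000 nM in this assay, at which 3 of the 4 values shown sit.

The compounds shown leave open whether phenyl in place of thiophen-2-yl on the shared core changes growth inhibition at all in this assay.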